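A second core, the same aniline swap

A few compounds are considered here, and "the series" means these few. Any claim that something is new, unique, unknown or untested is made for them only; others in the source may bear on it.

Compound 1 `COc1cc2ncnc(Nc3cccc(Br)c3)c2cc1OCCCCC(=O)Nc1ccc(S(N)(=O)=O)cc1` and compound 3 `NS(=O)(=O)c1ccc(NC(=S)Nc2ccc3ncnc(Nc4cccc(Br)c4)c3c2)cc1` both carry a 3-bromophenyl on a nitrogen on an aromatic ring, but the difference between their two cores is not broken down here. In a functional assay on A-431 cells (Homo sapiens) for antiproliferative activity, read by MTT assay, with a stated time of 72 h (on this read-out lower numbers stand for stronger inhibition and higher numbers for weaker inhibition), compound 1 gives 9750 nM, while compound 3 gives 20700 nM. Compound 2 `COc1cc2ncnc(Nc3ccc(C(F)(F)F)cc3)c2cc1OCCCCC(=O)Nc1ccc(S(N)(=O)=O)cc1` is compound 1 with one change, (4-(trifluoromethyl)phenyl in place of 3-bromophenyl on a nitrogen on an aromatic ring), and that change made a step of a 1.7-fold higher number from compound 1 to compound 2 (0.24 log units; within the scatter). In this assay compound 2 gives 16900 nM. Compound 4 `NS(=O)(=O)c1ccc(NC(=S)Nc2ccc3ncnc(Nc4ccc(C(F)(F)F)cc4)c3c2)cc1` carries the same change on the core of compound 3, (4-(trifluoromethyl)phenyl in place of 3-bromophenyl on a nitrogen on an aromatic ring), with the place matching word for word. Because the earlier step was a 1.7-fold higher number from compound 1 to compound 2 (0.24 log units; within the scatter), a step of similar size is expected here, a 1.4-fold higher number from compound 3 to compound 4 (0.13 log units; within the scatter). Compound 4 is therefore estimated at 28000 nM, most likely between 12000 nM and 70000 nM.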

Compound 4, half-maximal inhibitory concentration: 18000 nM
Compound 4: the middle estimate sits 1.6-fold (0.19 log units) above what was measured; low and high end bracket the measured number.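

In this assay the change gives a 1.2-fold lower number from compound 3 to compound 4 (0.06 log units; within the scatter), a step that lies within the scatter. Set beside the step on the core of compound 1, it does not differ by more than two such steps can: the same change on two cores in this assay, a 1.7-fold higher number (0.24 log units; within the scatter) from compound 1 to compound 2 and a 1.2-fold lower number (0.06 log units; within the scatter) from compound 3 to compound 4, 2.0-fold (0.30 log units) apart, within the scatter of two such steps. Going by these compounds alone, this shows that the change behaves alike on these two cores as far as this assay can tell, but it does not show a step of fixed size or direction, as neither step stands clear of the scatter and only two cores are compared.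

The compounds shown leave open how a pyridine ring or a phenyl carrying a carboxylic acid would read on that nitrogen. They also leave open what a longer chain in the linker of compound 1 would do.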